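Swapping Dichlorophenyl for Hydroxyphenyl at the Assay Limit

A few compounds are considered here, and "the series" means these few. Any claim that something is new, unique, unknown or untested is made for them only; others in the source may bear on it.

- Compound 1 `COc1ccc(/C=C/C(=O)c2ccc(OC)c3c2OC(C)(C)C=C3)c(F)c1`: 7560 nM
- Compound 2 `COc1ccc(C(=O)/C=C/c2ccc(Cl)cc2)c2c1C=CC(C)(C)O2`: > 10000 nM (a limit, not a number)
- Compound 3 `COc1ccc(C(=O)/C=C/c2ccc(Cl)c(Cl)c2)c2c1C=CC(C)(C)O2`: > 10000 nM (a limit, not a number)

All three compounds were tested in a functional assay on HepG2 cells (Homo sapiens) for antiproliferative activity, read by MTT assay, with a stated time of 24 h; a lower number here means a stronger inhibitor, a higher number a weaker inhibitor. Compound 3 gives only a limit of the assay, > 10000 nM. This is the limit of > 10000 nM in this assay, at which 2 of the 3 values shown sit.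

In compound 4 `COc1ccc(C(=O)/C=C/c2ccc(O)cc2)c2c1C=CC(C)(C)O2`, 4-hydroxyphenyl takes the place of 3,4-dichlorophenyl on a double-bonded chain carbon bound to a double-bonded chain carbon: 4-hydroxyphenyl in place of 3,4-dichlorophenyl on a double-bonded chain carbon bound to a double-bonded chain carbon.

Two measured steps changed the group at this place: an at least 1.3-fold higher number from compound 1 to compound 2 (0.12 log units; that floor lies within the scatter), and an at least 1.3-fold higher number from compound 1 to compound 3 (0.12 log units; that floor lies within the scatter). A third step added one chloro: a step that the two limits leave unreadable from compound 2 to compound 3. Going by the values given here, no measured compound carries 4-hydroxyphenyl. Among the compounds with values here, compound 1 at 7560 nM is the only true number here. No step beyond the scatter is expected in this assay, and another limit is quite possible.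

The expected change is a number no higher from compound 3 to compound 4 (the limit leaves the size open). For compound 4 the estimated value is 10000 nM, with an expected range from 4000 nM to 25000 nM.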

Compound 4, half-maximal inhibitory concentration: > 10000 nM
Compound 4: no number, only a limit; the forecaster's own chance of this, stated with the estimate: 55%; the middle value lies on the limit itself.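

In this assay compound 4 gives > 10000 nM, which is a limit of the assay and not a number. At this place, 4-hydroxyphenyl with its 1 hydrogen-bond donor thus ends at the same limit as 3,4-dichlorophenyl with 0 hydrogen-bond donors, and the steps that link compound 4 to compound 2 and compound 3 cannot be read. The one readable step is an at least 1.3-fold higher number from compound 1 to compound 4 (0.12 log units; that floor lies within the scatter), and the comparison stays blunt because of where the values sit: the limit of > 10000 nM in this assay, at which 3 of the 4 values shown sit.

On these data alone, how far these three compounds really lie from one another remains open, since a limit hides any true value. Also open, as far as these compounds go, is whether an amine or a carboxylic acid on this ring would give a true number.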